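This account rests on a few compounds, and the source may have more. Where it says the series, first, only, none or still open, it means among the compounds named here.

Measured in a functional assay on SW480 cells (Homo sapiens) for antiproliferative activity, with a stated time of 72 h; on this read-out higher numbers stand for weaker inhibition and lower numbers for stronger inhibition:
Compound 1 `O=C(COc1ccc(CNC2CC=C(c3c[nH]c4ccc(F)cc34)CC2)c(F)c1)NO`: 179 nM
Compound 2 `Cc1ccc2[nH]cc(C3=CCC(NCc4ccc(OCC(=O)NO)cc4F)CC3)c2c1`: 2780 nM

Of these two, compound 2 stands highest, at 2780 nM. Compound 3 `O=C(COc1ccc(CNC2CC=C(c3c[nH]c4ccccc34)CC2)c(F)c1)NO` has not yet been measured in this assay. It differs from compound 2 by hydrogen in place of methyl on an aromatic carbon. Going by the values given here, one measured step bears on this change, methyl in place of fluoro on that same carbon, and it was large: a 16-fold higher number from compound 1 to compound 2 (1.19 log units; beyond the scatter). Among the compounds with values here, no measured compound carries hydrogen there, so this step is only an indirect guide. On that evidence, removing the methyl is expected to give a large move towards a lower number, an estimated 9.3-fold lower number from compound 2 to compound 3 (0.97 log units; beyond the scatter). Compound 3 is expected at about 300 nM, with an estimated range of 100 nM to 900 nM.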

Compound 3, half-maximal inhibitory concentration: 1150 nM
Beside the measured number, compound 3's estimate is 3.8-fold (0.58 log units) below it; the measured number lies above the stated range.
By their numbers in this assay, from the lowest: compound 1; then compound 3; then compound 2.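

With hydrogen on this carbon, the series gains the reference that the fluoro and methyl compounds alone could not supply. In this assay, removing the methyl gives a 2.4-fold lower number from compound 2 to compound 3 (0.38 log units; beyond the scatter), while replacing the fluoro with hydrogen gives a 6.4-fold higher number from compound 1 to compound 3 (0.81 log units; beyond the scatter). The large difference first seen thus divides into two modest steps, so that, relative to hydrogen, methyl goes with a higher number and fluoro with a lower one. Nothing measured here explains why these groups act in opposite directions.

The three compounds leave open whether another group on this carbon, such as chloro, methoxy or a nitrile, would fall within the span set by fluoro and methyl. They also leave open whether a group such as ethyl would raise the number further than methyl.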